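The compounds below may be only part of what the source reports. "The series", "measured", "known", "first", "only" and "open" are said of these compounds alone.

Three compounds have so far been measured in a functional assay on DU-145 cells (Homo sapiens) for antiproliferative activity, read by propidium iodide staining, with a stated time of 96 h; on this read-out lower numbers stand for stronger inhibition and higher numbers for weaker inhibition:

Compound 1 `CC(O)(CS(=O)(=O)c1cccc(C(F)(F)F)c1)C(=O)Nc1ccc(S(F)(F)(F)(F)F)cc1` gives 31900 nM.
Compound 2 `CC(O)(CS(=O)(=O)c1ccccc1C(F)(F)F)C(=O)Nc1ccc(S(F)(F)(F)(F)F)cc1` gives 29400 nM.
Compound 3 `CC(O)(CS(=O)(=O)c1cccc(C(F)(F)F)c1)C(=O)Nc1cccc(S(F)(F)(F)(F)F)c1` gives 37300 nM.

Compounds 1 and 2 share a core and differ by 2-(trifluoromethyl)phenyl in place of 3-(trifluoromethyl)phenyl on a sulfonyl sulfur. This change gave a 1.1-fold lower number from compound 1 to compound 2 (0.04 log units; within the scatter), so the two values cannot be told apart. Compound 3 carries a different core from compound 1; the difference between the two cores is not broken down here, and the values of compound 1 and compound 3 lie within the scatter of each other, as do those of compound 2 and compound 3.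

Compound 4 `CC(O)(CS(=O)(=O)c1ccccc1C(F)(F)F)C(=O)Nc1cccc(S(F)(F)(F)(F)F)c1` has not yet been measured. It differs from compound 3 by 2-(trifluoromethyl)phenyl in place of 3-(trifluoromethyl)phenyl on a sulfonyl sulfur, which is the same change as that from compound 1 to compound 2, at a place described in the same words. Because that earlier step gave a 1.1-fold lower number from compound 1 to compound 2 (0.04 log units; within the scatter), the step from compound 3 to compound 4 in this assay is expected to be about a 1.1-fold lower number from compound 3 to compound 4 (0.04 log units; within the scatter), essentially no change. On that basis compound 4 is estimated at 34000 nM, with a likely range from 17000 nM to 70000 nM.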

Compound 4, half-maximal inhibitory concentration: 27300 nM
Estimate against measurement, compound 4: 1.2-fold (0.10 log units) above; low and high end bracket the measured number.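

In this assay, 2-(trifluoromethyl)phenyl in place of 3-(trifluoromethyl)phenyl on a sulfonyl sulfur gave a 1.4-fold lower number from compound 3 to compound 4 (0.14 log units; within the scatter), so this step cannot be told from no change. Set beside the earlier step, the result on the second core agrees with that on the first: the same change on two cores in this assay, a 1.1-fold lower number (0.04 log units; within the scatter) from compound 1 to compound 2 and a 1.4-fold lower number (0.14 log units; within the scatter) from compound 3 to compound 4, 1.3-fold (0.10 log units) apart, within the scatter of two such steps. This shows that the absence of a measurable effect carried from one core to the other, but it does not show that a change with a real effect would carry over, and two cores make no rule for the series.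

The compounds shown leave open what a nitrile or a methoxy group in place of the trifluoromethyl group would do. They also leave open the effect of an amine in place of the hydroxyl group.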